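The compounds below may be only part of what the source reports. "The series", "measured", "known", "first", "only" and "open" are said of these compounds alone.

The measured compounds, each with its structure and its result in a functional assay on thoracic aorta (Rattus norvegicus, strain Wistar), with a stated time of 15 min; a lower number here means that less compound is needed, a higher number that more compound is needed for the effect:

Compound 1, `CCOc1ccc(Cl)cc1C(C)NC(=O)N(C)S(=O)(=O)c1ccccc1`, gives 10500 nM in this assay.
Compound 3, `CCOc1ccc(F)cc1C(C)NC(=O)N(C)S(=O)(=O)c1ccccc1`, gives 11500 nM in this assay.
Compound 2, `COc1ccc(F)cc1C(C)NC(=O)NS(=O)(=O)c1ccc(C)cc1`, gives only a limit of the assay, > 300000 nM, in this assay.

Compound 1 and compound 3 share one core, and the change between them is chloro in place of fluoro on an aromatic carbon. That change made a step of a 1.1-fold lower number from compound 3 to compound 1 (0.04 log units; within the scatter), a step that does not count as a real difference between the two compounds.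

Compound 2 stands on a different core; the difference between the two cores is not broken down here. What is known of compound 2 is the limit (the limit of > 300000 nM in this assay, at which 1 of the 3 values shown sits).

The compound still to be measured is compound 4, `COc1ccc(Cl)cc1C(C)NC(=O)NS(=O)(=O)c1ccc(C)cc1`. It comes from compound 2 by chloro in place of fluoro on an aromatic carbon. Within the data shown here, this is the same kind of change as the one from compound 3 to compound 1, though not the same: in compound 1 the chloro sits para to an ethoxy group (3 heavy atoms), in compound 4 it sits para to a methoxy group (2 heavy atoms).

For the step from compound 2 to compound 4 in this assay, the expectation is a number no higher from compound 2 to compound 4 (the limit leaves the size open), beside the measured step of a 1.1-fold lower number from compound 3 to compound 1 (0.04 log units; within the scatter); this rests on that measured step being within the scatter. Compound 4 is therefore estimated at 300000 nM, expected to lie between 100000 nM and 1000000 nM, and it is quite possible that compound 4 will again give only a limit.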

Compound 4, half-maximal effective concentration: > 300000 nM
Compound 4 gave a limit, no number; the forecaster's own chance of this, stated with the estimate: 70%; the middle value lies on the limit itself.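

In this assay compound 4 gives > 300000 nM, a limit of the assay and not a number. Among these compounds, compound 2 gives > 300000 nM, also a limit, so no step between compound 2 and compound 4 can be read. The compounds shown leave open where the true values of compound 2 and compound 4 lie, and whether chloro in place of fluoro makes any real difference on their core.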